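A Second Chloro Group on the Core of Compound 1

This account rests on a few compounds, and the source may have more. Where it says the series, first, only, none or still open, it means among the compounds named here.

Compound 1 `Cc1c(C#Cc2ccc(CCC(=O)O)cc2)ccnc1Cl` gives 101% in an in vitro functional assay on 1321-N1 cells for agonist activity at Free fatty acid receptor 1 (Homo sapiens), read by fluorescence, spectrophotometry and calcium flux (on this read-out higher numbers stand for larger maximal responses and lower numbers for smaller maximal responses), the higher of the two numbers measured, though its difference to compound 2 lies within the scatter. Going by the values given here, compound 2 `O=C(O)CCc1ccc(C#Cc2ccnc(Cl)c2)cc1` gives 94% in this assay; the single measured step, a number 7 percentage points lower from compound 1 to compound 2 (within the scatter), belongs to hydrogen in place of methyl on an aromatic carbon. Compound 3 `Cc1c(C#Cc2ccc(CCC(=O)O)cc2)cc(Cl)nc1Cl` has not been measured in this assay. It differs from compound 1 by chloro in place of hydrogen on an aromatic carbon. Among the compounds with values here, no measured step puts a chloro group at this site, so the step from compound 1 to compound 2 bears on it only in showing that a small change on the core of compound 1 left the maximal response unchanged within the scatter. Compound 3 is therefore expected to show a number 5 percentage points lower from compound 1 to compound 3 (within the scatter), no step beyond the scatter. The estimate for compound 3 is 96%, within a range from 82% to 108%.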

Compound 3, largest response reached (reported as efficacy), in percent of the reference or control that the assay uses: 91%
Compound 3: middle estimate off by 5 percentage points, on the high side; the range from low to high includes it.
By their numbers in this assay, from the lowest: compounds 3, 2 and 1 (each within the scatter of the next).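

A chloro group at this position, on the aromatic carbon next to the ring nitrogen and para to the methyl group, leaves the maximal response in this assay within the scatter: the measured change is a number 10 percentage points lower from compound 1 to compound 3 (within the scatter), with the methyl group kept in place. Going by these compounds alone, the earlier compounds showed only the removal of the methyl group, whereas this step adds a heavy atom at a different site on the core and gives the first direct reading for this position. Nothing measured here explains this outcome.

The compounds shown leave open whether an amine or a methoxy group at this position would also keep the maximal response within the scatter of compound 1. They also leave open whether a chloro group here would give the same reading with hydrogen in place of the methyl group.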